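Swapping a Nonyl Chain for Cyclohexyl on a Urea Nitrogen

The source may hold more compounds than are shown below. What is called first, only, known or untested is meant among the compounds shown, and "the series" means these compounds.

Measured so far:
- Compound 1, `CCCCCCCCCNC(=O)N(Cc1cc(OC)ccc1OC)n1cnnc1`: in a functional assay on MDA-MB-231 cells (Homo sapiens) for cytotoxicity, read by MTT assay, with a stated time of 48 h (a lower number here means a stronger inhibitor, a higher number a weaker inhibitor), compound 1 gives > 50000 nM, which is a limit of the assay and not a number.
- Compound 2, `CC1CCC(NC(=O)N(Cc2ccccn2)n2cnnc2)CC1`: in this assay compound 2 gives 33200 nM.

Compound 1 therefore stands at the weak end of what this assay can report, with only a limit known for it (the limit of > 50000 nM in this assay, at which 1 of the 2 values shown sits). Compound 2 shares the core but carries other groups at both ends, so its value says nothing directly about any single change.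

Compound 3, `COc1ccc(OC)c(CN(C(=O)NC2CCCCC2)n2cnnc2)c1`, differs from compound 1 in one place: cyclohexyl in place of nonyl on an amide-type nitrogen. Going by the values given here, no step between measured compounds isolates this change, and both measured values sit at or near the weak end, so no step beyond the scatter is expected in this assay for this exchange; the expected step from compound 1 to compound 3 is an at least 1.2-fold lower number from compound 1 to compound 3 (0.09 log units; that floor lies within the scatter). Compound 3 is therefore estimated at 40000 nM, with a range from 15000 nM to 100000 nM, and a real chance that only a limit is reported.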

Compound 3, half-maximal inhibitory concentration: > 50000 nM
Compound 3: no number, only a limit (the forecaster's own chance of this, stated with the estimate: 55%); at least 1.2-fold (0.09 log units) between middle value and limit.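

Compound 1 and compound 3 each carry only a limit in this assay, not a number, and no step can be read between them for cyclohexyl in place of nonyl. The compounds shown leave open whether this exchange changes the result at all, given where the values sit: the limit of > 50000 nM in this assay, at which 2 of the 3 values shown sit.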